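Shortening the Side Chain of Compound 1

A few compounds are considered here, and "the series" means these few. Any claim that something is new, unique, unknown or untested is made for them only; others in the source may bear on it.

Compound 1 `CN(CCCN1CCCCC1)c1ccc(C(=O)N2CCc3ccc(OS(N)(=O)=O)cc3C2)cc1` carries a methyl(3-(piperidin-1-yl)propyl)amino group, and in an assay on HEK293 cells for inhibition of Steryl-sulfatase (Homo sapiens), tested at 1 uM (a higher number here means a stronger effect of the compound at the concentration tested, a lower number a weaker effect), compound 1 gives 40.7%, the lowest of the three numbers in hand. Compound 2 `CCN(Cc1ccc(F)cc1)c1cccc(C(=O)N2CCc3ccc(OS(N)(=O)=O)cc3C2)c1` gives 66.5%, and compound 3 `NS(=O)(=O)Oc1ccc2c(c1)CN(C(=O)c1cccc(N3CCc4ccccc4C3)c1)CC2` gives 50.2%; compound 3 sits within the scatter of compound 1, while compound 2 stands beyond it. Going by the values given here, the one measured step, a number 16.3 percentage points lower from compound 2 to compound 3 (beyond the scatter), concerns the exchange of a different substituent, so it does not bear directly on the change considered here.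

Compound 4 `CN(CCN1CCCCC1)c1ccc(C(=O)N2CCc3ccc(OS(N)(=O)=O)cc3C2)cc1` differs from compound 1 in one place: piperidin-1-yl in place of (piperidin-1-yl)methyl on a saturated chain carbon, two bonds along the chain from a nitrogen on an aromatic ring. Among the compounds with values here, no measured pair reports a change of this kind, and the single step recorded anywhere in the set is only modest. Compound 4 is therefore expected to stay close to compound 1, with a step of a number 0.3 percentage points higher from compound 1 to compound 4 (within the scatter) that should remain within the usual scatter. The estimate for compound 4 in this assay is 41%, with a range from 25% to 58%.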

Compound 4, a percentage reported as inhibition, at one concentration (the size of the read-out at that concentration, not a potency): 26.8%
The estimate for compound 4 lay 14.2 percentage points above the measured number, and the stated range covers the measured number.
By their numbers in this assay, from the lowest: compound 4; then compounds 1 and 3 (each within the scatter of the next); then compound 2.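

Going from the methyl(3-(piperidin-1-yl)propyl)amino group of compound 1 to the methyl(2-(piperidin-1-yl)ethyl)amino group of compound 4 gives, in this assay, a number 13.9 percentage points lower from compound 1 to compound 4 (beyond the scatter), the only measured change of chain length among the compounds shown. It shows that the read-out responds to this chain: the shorter 2-(piperidin-1-yl)ethyl chain on the aromatic nitrogen lowers the number beyond the scatter, although the piperidine ring itself is unchanged. Nothing available explains this step.

Going by these compounds, whether a longer chain than 3-(piperidin-1-yl)propyl would raise the number remains open, as does whether a morpholine or a dimethylamino group at the chain end would respond to shortening in the same way. A single step also cannot establish a trend with chain length.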